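The source may hold more compounds than are shown below. What is called first, only, known or untested is meant among the compounds shown, and "the series" means these compounds.

Measured so far in a functional assay on HepG2 cells (Homo sapiens) for cytotoxicity, read by MTT assay, with a stated time of 72 h; a lower number here means a stronger inhibitor, a higher number a weaker inhibitor:
Compound 1, `CNC(=O)c1cc(Oc2ccc(NC(=O)c3nn(-c4ccc(Br)cc4F)c(=O)cc3C)cc2F)ccn1`: 2830 nM.
Compound 2, `CNC(=O)c1cc(Oc2ccc(NC(=O)c3nn(-c4cccc(F)c4)c(=O)cc3C)cc2F)ccn1`: 10200 nM.
Compound 3, `CNC(=O)c1cc(Oc2ccc(NC(=O)c3nn(-c4ccccc4F)c(=O)cc3C)cc2F)ccn1`: only a limit of the assay, > 40000 nM.

Among the numbers, compound 1 stands lowest; compound 2 is nearest, with a 3.6-fold higher number from compound 1 to compound 2 (0.56 log units; beyond the scatter). Compound 3 sits at the limit of > 40000 nM in this assay, at which 1 of the 3 values shown sits. The steps of an at least 14-fold higher number from compound 1 to compound 3 (1.15 log units; beyond the scatter) and an at least 3.9-fold higher number from compound 2 to compound 3 (0.59 log units; beyond the scatter) show that changes to the aryl on the aromatic nitrogen move this assay by modest to large amounts.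

Compound 4, `Cc1cc(=O)n(-c2ccc(Br)cc2F)nc1C(=O)Nc1ccc(Oc2ncnc3ccsc23)c(F)c1`, differs from compound 1 elsewhere: a group of 9 heavy atoms (6 carbon, 2 nitrogen, 1 sulfur; one five-membered aromatic ring with 1 hetero atom, one six-membered aromatic ring with 2 hetero atoms) in place of a group of 10 heavy atoms (7 carbon, 2 nitrogen, 1 oxygen; one six-membered aromatic ring with 1 hetero atom), on an oxygen on an aromatic ring. Among the measured compounds shown here, none of the measured steps touches this part of the shared core, and they give no direction for this change. The step from compound 1 to compound 4 is therefore expected to be a 1.1-fold higher number from compound 1 to compound 4 (0.03 log units; within the scatter), with wide uncertainty. Compound 4 is estimated at 3000 nM, between 700 nM and 13000 nM.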

Compound 4, half-maximal inhibitory concentration: 3350 nM
Estimate against measurement, compound 4: 1.1-fold (0.05 log units) below; the range from low to high includes it.
By their numbers in this assay, from the lowest: compounds 1 and 4 (each within the scatter of the next); then compound 2. At a limit, above all of these: compound 3.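

Replacing the 2-(methylcarbamoyl)pyridin-4-yl group on the oxygen with a group of one five-membered and one six-membered aromatic ring leaves this assay essentially unchanged, with a 1.2-fold higher number from compound 1 to compound 4 (0.07 log units; within the scatter). This position therefore accepts one complete change of group, including loss of the hydrogen-bond donor, without a shift beyond the scatter, unlike the changes to the aryl on the aromatic nitrogen. Nothing measured here accounts for this result.

As far as these compounds go, whether this holds with the aryl groups of compound 2 or compound 3 remains open. So does the outcome with a plain phenyl or an aminopyridine on this oxygen.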